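Replacing 4-fluoro-1H-indol-3-yl in compound 1

The source may hold more compounds than are shown below. What is called first, only, known or untested is meant among the compounds shown, and "the series" means these compounds.

Within the data shown here, in a functional assay on HCT-116 cells (Homo sapiens) for antiproliferative activity, with a stated time of 72 h (a higher number here means a weaker inhibitor, a lower number a stronger inhibitor), compound 1 `O=C(COc1ccc(CNC2CC=C(c3c[nH]c4cccc(F)c34)CC2)c(F)c1)NO` gives 173 nM, the only actual number available so far. Compound 2 `O=C(COc1ccc(CN2CC=C(c3c[nH]c4ccc(F)cc34)CC2)c(F)c1)NO` gives > 5000 nM, which is a limit of the assay and not a number. Compound 3 `Cc1ccc2[nH]cc(C3=CCC(NCc4ccc(OCC(=O)NO)cc4F)CC3)c2c1` has not yet been measured and differs from compound 1 in one place: 5-methyl-1H-indol-3-yl in place of 4-fluoro-1H-indol-3-yl on a double-bonded ring carbon. In words, 5-methyl-1H-indol-3-yl stands in place of 4-fluoro-1H-indol-3-yl on a double-bonded ring carbon. Among the measured compounds shown here, no measured step covers this change, so the expectation rests mainly on compound 1 at 173 nM. A modest move toward weaker inhibition in this assay, not far beyond the usual scatter, is expected, and the estimated step is a 1.4-fold higher number from compound 1 to compound 3 (0.16 log units; within the scatter). The estimate for compound 3 is 250 nM, with the result expected to fall between 80 nM and 800 nM.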

Compound 3, half-maximal inhibitory concentration: 445 nM
Compound 3: middle estimate off by 1.8-fold (0.25 log units), on the low side; the range from low to high includes it.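

In this assay, among these compounds, the change to 5-methyl-1H-indol-3-yl gives the first readable step at this place, a 2.6-fold higher number from compound 1 to compound 3 (0.41 log units; beyond the scatter), so the position does respond to what the indole carries, while compound 3 still gives a measured value. The entering and leaving groups match in heavy atoms, hydrogen-bond donors and hydrogen-bond acceptors, so the step comes with a swap that these counts do not register: a fluorine gone, a methyl present, and the substituent's place on the indole changed. Nothing at hand explains the size of this step.

The compounds shown leave open whether the step follows the identity of the substituent or its place on the indole, which 4-methyl-1H-indol-3-yl would help to separate. Going by these compounds, how a nitrile or a methoxy group would read at this position also remains open.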